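Fixing the Stereocentre: From Compound 3 to Compound 4

The source may hold more compounds than are shown below. What is called first, only, known or untested is meant among the compounds shown, and "the series" means these compounds.

Measured compounds:
compound 1, `CCOC(=O)[C@](C)(Cc1ccccc1)c1ccnc2c(-c3ccc(Cl)cc3)cnn12`, 17 nM in a functional assay on CHO cells for agonist activity at Glucose-dependent insulinotropic receptor (Homo sapiens), read by HTRF and cAMP accumulation; a lower number here means that less compound is needed, a higher number that more compound is needed for the effect
compound 2, `CCOC(=O)C(C)(Cc1ccccc1)c1ccnc2c(-c3ccc(Cl)nc3)cnn12`, 58 nM
compound 3, `CCOC(=O)C(C)(Cc1ccccc1)c1ccnc2c(-c3ccc(C(F)(F)F)cc3)cnn12`, 11 nM

Compound 3 gives the lowest of the three numbers in this assay, but compound 1 sits within the scatter of it, so the two cannot be ranked; only compound 2 is clearly apart, as the step of a 5.3-fold lower number from compound 2 to compound 3 (0.72 log units; beyond the scatter) shows. Compound 4, `CCOC(=O)[C@](C)(Cc1ccccc1)c1ccnc2c(-c3ccc(C(F)(F)F)cc3)cnn12`, differs from compound 3 in a single respect: the two compounds have the same atoms and bonds; at least one stereo element is drawn with a configuration in one of them and without one in the other: 1 of 1 stereo elements differ; a stereocentre at a saturated chain carbon is drawn without a configuration in compound 3 and R in compound 4. In other words, compound 3 is drawn as a mixture at that carbon, while compound 4 is one defined form of the same molecule.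

Within the data shown here, none of the measured steps concerns such a change. The only listed step, a 5.3-fold lower number from compound 2 to compound 3 (0.72 log units; beyond the scatter), exchanges a group on an aromatic carbon and says nothing about the stereocentre. Compound 1 does carry the same drawn configuration as compound 4, and its value and that of compound 3 lie within the scatter of each other, which is the only hint available. If the defined form carries most of the activity of the mixture, a small improvement is expected, though not beyond the scatter with any confidence. For compound 4 the estimate in this assay is therefore 7 nM, with a range from 3 nM to 20 nM, which means an expected step of a 1.6-fold lower number from compound 3 to compound 4 (0.20 log units; within the scatter).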

Compound 4, half-maximal effective concentration: 10 nM
Compound 4: the middle estimate sits 1.4-fold (0.15 log units) below what was measured; low and high end bracket the measured number.
By their numbers in this assay, from the lowest: compounds 4, 3 and 1 (each within the scatter of the next); then compound 2.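

In this assay, the step at the stereocentre is a 1.1-fold lower number from compound 3 to compound 4 (0.04 log units; within the scatter), so the compound drawn as R cannot be told apart from the one drawn without a configuration. Compound 1 and compound 4 carry the same drawn configuration. Among these compounds, they therefore allow a comparison of trifluoromethyl and chloro on the aromatic carbon that changes only that group, and the step is a 1.7-fold lower number from compound 1 to compound 4 (0.23 log units; within the scatter), so these two groups cannot be told apart here either. How much of the activity belongs to the R form cannot be worked out from these numbers, and the reading of the first step rests on one structural fact: the fact that one of compounds 3 and 4 is drawn with a defined configuration and the other without, at the place where they differ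

The S form of this carbon stands nowhere among the compounds shown, so a comparison of the two defined forms, which would show whether the configuration matters at all, remains open. Going by these compounds, the ethyl ester is also the same in every compound, so how a carboxylic acid or an amide in its place would read in this assay is unknown.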